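Exchanging fluoro for chloro in compound 2

The source may hold more compounds than are shown below. What is called first, only, known or untested is meant among the compounds shown, and "the series" means these compounds.

Compound 1 `COc1cc(/C=C2\CN(C)C/C(=C\c3ccccc3F)C2=O)cc(OC)c1`: 11900 nM
Compound 2 `COc1cc(/C=C2\CN(C)C/C(=C\c3ccc(F)cc3)C2=O)cc(OC)c1`: 21900 nM

Going by the values given here, in an ADME assay on L02 cells (Homo sapiens) for cytotoxicity, read by MTT assay, with a stated time of 24 h (a lower number here means a stronger inhibitor, a higher number a weaker inhibitor), compound 2 stands within the scatter of compound 1, the only other compound measured. Compound 3 `COc1cc(/C=C2\CN(C)C/C(=C\c3ccc(Cl)cc3)C2=O)cc(OC)c1` differs from compound 2 in one place, with chloro in place of fluoro on an aromatic carbon. Among the compounds with values here, the sole measured step, a 1.8-fold higher number from compound 1 to compound 2 (0.26 log units; within the scatter), moves the fluoro instead of exchanging it, and it stays within the scatter. Within the data shown here, no measured step covers this exchange, so no shift beyond the scatter is expected. The estimated value for compound 3 is 16000 nM, with a range of 7000 nM to 35000 nM. This estimate means an expected 1.4-fold lower number from compound 2 to compound 3 (0.14 log units; within the scatter).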

Compound 3, half-maximal inhibitory concentration: 18900 nM
For compound 3 the middle estimate is 1.2-fold (0.07 log units) below the measured one; the range from low to high includes it.
By their numbers in this assay, from the lowest: compounds 1, 3 and 2 (each within the scatter of the next).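

In this assay, exchanging the halogen itself on this aromatic carbon (a 1.2-fold lower number from compound 2 to compound 3 (0.06 log units; within the scatter)) stays within the scatter, whereas the earlier compounds had shown only a move of the fluoro. Changing both the halogen and its place, with 4-chlorophenyl in place of 2-fluorophenyl (a 1.6-fold higher number from compound 1 to compound 3 (0.20 log units; within the scatter)), also stays within the scatter, so none of these changes separates the three compounds. Nothing measured here offers an explanation for this result.

Still open, as far as these compounds go, is whether a group other than a halogen on this aromatic carbon, such as an amine or a carboxylic acid, would give a step beyond the scatter.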